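Compound 3 to compound 4: 2-chlorophenyl for 4-methylphenyl

The source may hold more compounds than are shown below. What is called first, only, known or untested is meant among the compounds shown, and "the series" means these compounds.

Compound 3 `COc1cc(/C=C/C(C)=O)ccc1OCc1cn(-c2ccc(C)cc2)nn1` gives > 100000 nM in a functional assay on MCF7 cells (Homo sapiens) for antiproliferative activity, read by MTT assay, with a stated time of 48 h (a lower number here means a stronger inhibitor, a higher number a weaker inhibitor), which is a limit and not a number. Compound 2 `COc1cc(/C=C/C(C)=O)ccc1OCc1cn(-c2ccc([N+](=O)[O-])cc2)nn1` gives > 100000 nM, also a limit. Going by the values given here, compound 1 `COc1cc(/C=C/C(C)=O)ccc1OCc1cn(-c2c(Cl)cccc2Cl)nn1`, with its 2,6-dichlorophenyl group, gives the only true number, 26600 nM.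

Compound 4 `COc1cc(/C=C/C(C)=O)ccc1OCc1cn(-c2ccccc2Cl)nn1` carries 2-chlorophenyl in place of 4-methylphenyl on an aromatic nitrogen.

Among the compounds with values here, two measured steps bear on this change: an at least 3.7-fold higher number from compound 1 to compound 3 (0.57 log units; beyond the scatter) and an at least 3.7-fold higher number from compound 1 to compound 2 (0.57 log units; beyond the scatter). Both leave the 2,6-dichlorophenyl group and both end at a limit, so each gives only a minimum size. The step that the two limits leave unreadable from compound 2 to compound 3 adds no readable size. Within the data shown here, the entering group is the only one among those in compounds 2 and 3 that keeps chlorine on the ring, so a modest move toward lower numbers is expected in this assay, and a result still at the limit remains possible.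

The expected step is an at least 1.6-fold lower number from compound 3 to compound 4 (0.22 log units; that floor lies within the scatter).

For compound 4 the estimated value is 60000 nM, with an expected range of 22000 nM to 160000 nM.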

Compound 4, half-maximal inhibitory concentration: 2190 nM
Compound 4: the middle estimate sits 27-fold (1.44 log units) above what was measured; measured number outside the range, below it.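

In this assay, 2-chlorophenyl on the aromatic nitrogen gives an at least 45-fold lower number from compound 3 to compound 4 (1.65 log units; beyond the scatter) and an at least 45-fold lower number from compound 2 to compound 4 (1.65 log units; beyond the scatter), so at this position the choice of aryl group separates a readable value from the assay limit, even among groups of equal heavy-atom count. Hydrogen in place of one chloro group gives a 12-fold lower number from compound 1 to compound 4 (1.08 log units; beyond the scatter), so the second chlorine of 2,6-dichlorophenyl is not needed for activity in this set, and the single chlorine gives the lower number. The first two steps are minimum sizes only, and the step between compound 2 and compound 3 cannot be read: the limit of > 100000 nM in this assay, at which 2 of the 4 values shown sit.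

Open, as far as these compounds go, is whether bromine, methoxy or an amine could take the place of the chlorine of compound 4 with the same result, and how plain phenyl would compare. Also open, from the compounds shown here alone, is how much depends on chlorine itself and how much on where it sits, as compound 4 differs from compound 2 and compound 3 in both.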